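The compounds below may be only part of what the source reports. "The series", "measured", "known", "first", "only" and "open" are said of these compounds alone.

Compound 2 `CN1CCC(N2CC(COCc3cc(C(F)(F)F)cc(C(F)(F)F)c3)(c3ccc(F)cc3)NC2=O)CC1` gives 0.4 nM in an assay on CHO cells for displacement of a labelled ligand from Substance-P receptor (Homo sapiens) (on this read-out lower numbers stand for stronger inhibition and higher numbers for weaker inhibition), the lowest of the two numbers recorded here. Its nearest neighbour is compound 1 `O=C1NC(COCc2cc(C(F)(F)F)cc(C(F)(F)F)c2)(c2ccc(F)cc2)CN1C1CCOCC1`, which gives 6.3 nM; the only difference between them lies on the amide-type nitrogen in the ring, and the step of a 16-fold lower number from compound 1 to compound 2 (1.20 log units; beyond the scatter) is large. Compound 3 `O=C1NC(COCc2cc(C(F)(F)F)cc(C(F)(F)F)c2)(c2ccc(F)cc2)CN1CCN1CCCC1` is built from the same atoms as compound 2 but joined differently: 2-(pyrrolidin-1-yl)ethyl in place of 1-methylpiperidin-4-yl on an amide-type nitrogen in a ring. Among the measured compounds shown here, no measured step covers this exact exchange. For the measured compounds named here, the one step recorded shows that the group on this ring nitrogen can shift the number strongly, yet compound 3 keeps a nitrogen-bearing ring there, so a far smaller movement is expected than from compound 1 to compound 2. The estimate for compound 3 is 1 nM, with a range from 0.3 nM to 4 nM, meaning an expected step of a 2.5-fold higher number from compound 2 to compound 3 (0.40 log units; beyond the scatter).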

Compound 3, inhibition constant: 1.6 nM
Estimate against measurement, compound 3: 1.6-fold (0.20 log units) below; low and high end bracket the measured number.
By their numbers in this assay, from the lowest: compound 2; then compound 3; then compound 1.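

In this assay the same atoms, rearranged from 1-methylpiperidin-4-yl into 2-(pyrrolidin-1-yl)ethyl, give a 4.0-fold higher number from compound 2 to compound 3 (0.60 log units; beyond the scatter) and so the arrangement on this amide-type nitrogen counts, not just its atom content. The ring need not sit directly on that nitrogen, since replacing oxan-4-yl with the 2-(pyrrolidin-1-yl)ethyl group still gives a 3.9-fold lower number from compound 1 to compound 3 (0.60 log units; beyond the scatter) and both nitrogen-bearing groups here end up on the lower side of compound 1. Nothing available explains why these groups rank as they do.

The compounds shown leave open how the number responds to a longer chain such as 3-(pyrrolidin-1-yl)propyl, or to an open amine such as 2-(dimethylamino)ethyl. They also leave open whether the methyl on the piperidine matters, which piperidin-4-yl would test.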